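This account rests on a few compounds, and the source may have more. Where it says the series, first, only, none or still open, it means among the compounds named here.

Of the compounds shown here, three sharing one core have been measured in an assay on isolated protein for inhibition of ubiquitin carboxyl-terminal hydrolase 7 (Homo sapiens), read by fluorescence, with stated times of 30 min and 1 h; a higher number here means a weaker inhibitor, a lower number a stronger inhibitor. Compound 1 `Cc1cc(Cl)cc(-c2ccnc3cc(CN4C(=O)CCC4=O)sc23)c1O[C@H]1C[C@H](N)C1` gives 3.4 nM in this assay, the highest of the three numbers, which makes it the weakest inhibitor of the set. Compound 2 `Cc1cc(Cl)cc(-c2ccnc3cc(CN4C(=O)C5CC5C4=O)sc23)c1C[C@@H]1CNC[C@@H](C)O1` gives 0.39 nM in this assay, and compound 3 `Cc1cc(Cl)cc(-c2ccnc3cc(CN4C(=O)C5C(C4=O)C5(C)C)sc23)c1CC1CCCNC1` gives 1.3 nM; both of these numbers lie beyond the scatter from that of compound 1, but each of these compounds differs from compound 1 in more than one place, so the numbers cannot be tied to any single change.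

Compound 4 `Cc1cc(Cl)cc(-c2ccnc3cc(CN4C(=O)CCC4=O)sc23)c1O[C@H]1CCCNC1` differs from compound 1 in one place only: piperidin-3-yl in place of 3-aminocyclobutyl on an oxygen on an aromatic ring. Within the data shown here, no measured pair isolates this change, so its effect is not known. Compound 3 also contains a piperidin-3-yl group and gives 1.3 nM, yet it differs from compound 1 elsewhere too. The change is therefore expected to shift the number only modestly, a 1.4-fold lower number from compound 1 to compound 4 (0.13 log units; within the scatter), possibly not beyond the scatter. Compound 4 is expected to give about 2.5 nM in this assay, within a range from 0.7 nM to 10 nM.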

Compound 4, half-maximal inhibitory concentration: 4.6 nM
The estimate for compound 4 lay 1.8-fold (0.26 log units) below the measured number; measured number inside the range.
By their numbers in this assay, from the lowest: compound 2; then compound 3; then compounds 1 and 4 (each within the scatter of the next).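

Among these compounds, this is the first pair of compounds that differ in one place only: in this assay, piperidin-3-yl in place of 3-aminocyclobutyl on an oxygen on an aromatic ring gives a 1.4-fold higher number from compound 1 to compound 4 (0.13 log units; within the scatter). At this position, then, a six-membered non-aromatic ring holding its nitrogen within the ring and a four-membered carbon ring carrying an amino group cannot be told apart by this measurement, even though the two groups differ in ring size and in their defined stereocentres. Nothing available here explains this result.

Going by these compounds, it remains open whether the nitrogen matters at this position, which a cyclohexyl group or a carboxylic acid on the same oxygen would help to show. The steps to compound 2 and compound 3 cannot be read, as each differs from compound 1 in more than one place.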